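Replacing an Aromatic Group with a Carboxycyclohexyl

The compounds below may be only part of what the source reports. "The series", "measured", "known", "first", "only" and "open" are said of these compounds alone.

In a functional assay on BXPC-3 cells (Homo sapiens) for cytotoxicity, read by MTT assay (on this read-out lower numbers stand for stronger inhibition and higher numbers for weaker inhibition), compound 2 (`Oc1ccc(CN(Cc2cccc(C(F)(F)F)c2)Cc2ccc(O)c3ncccc23)c2cccnc12`) gives 167 nM and stands within the scatter of compound 1 (`Oc1ccc(CN(Cc2ccccc2C(F)(F)F)Cc2ccc(O)c3ncccc23)c2cccnc12`) at 274 nM while compound 3 (`Oc1ccc(CN(Cc2cc(C(F)(F)F)cc(C(F)(F)F)c2)Cc2ccc(O)c3ncccc23)c2cccnc12`) gives the lower 79 nM beyond that scatter. Compound 4 (`O=C(O)C1CCC(CN(Cc2ccc(O)c3ncccc23)Cc2ccc(O)c3ncccc23)CC1`) is unmeasured and carries 4-carboxycyclohexyl in place of 3-(trifluoromethyl)phenyl on a saturated chain carbon bound to an amine nitrogen. The step of a 1.6-fold lower number from compound 1 to compound 2 (0.22 log units; within the scatter) stays within the scatter, and the modest step of a 2.1-fold lower number from compound 2 to compound 3 (0.33 log units; beyond the scatter) comes with one added trifluoromethyl. Neither step replaces the aromatic ring, so both guide only weakly. In this assay the expected step of a 4.2-fold higher number from compound 2 to compound 4 (0.62 log units; beyond the scatter) therefore points to a higher number, beyond the scatter. Compound 4 is estimated at 700 nM (170 nM to 3500 nM).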

Compound 4, half-maximal inhibitory concentration: 4340 nM
Compound 4: middle estimate off by 6.2-fold (0.79 log units), on the low side; the whole stated range lies below it.
By their numbers in this assay, from the lowest: compound 3; then compounds 2 and 1 (each within the scatter of the next); then compound 4.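

In this assay, the position on a saturated chain carbon bound to an amine nitrogen tolerates moving or adding trifluoromethyl far better than losing the aromatic ring altogether. Placing 4-carboxycyclohexyl there gives a 26-fold higher number from compound 2 to compound 4 (1.41 log units; beyond the scatter) and a 16-fold higher number from compound 1 to compound 4 (1.20 log units; beyond the scatter) and both steps are large, well beyond any seen among the earlier compounds. No measurement shown gives a reason for this rise. On these data alone, each step changes the ring and its substituent together, so their separate shares remain open. A plain cyclohexyl, or a phenyl ring carrying a carboxylic acid, would tell them apart.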